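Chloro for Trifluoromethyl in a Permeability Comparison

The compounds below may be only part of what the source reports. "The series", "measured", "known", "first", "only" and "open" are said of these compounds alone.

For the measured compounds named here, only two compounds have results in an ADME assay on LLC-PK1 cells (Sus scrofa) for permeability, with a stated time of 3 h, tested at 1 uM; a lower number here means that the compound crosses the layer more slowly, a higher number that the compound crosses the layer faster. For compound 1 `O=C(O)CNC(=O)c1c(O)c2c(n(Cc3ccc(C(F)(F)F)nc3)c1=O)CCOC2`, the result is a limit of the assay, < 1.7 10^-6 cm/s. Going by the values given here, compound 2 `O=C(O)CNC(=O)c1c(O)c2c(n(Cc3ccc(C(F)(F)F)cc3)c1=O)COC2` gives 4.2 10^-6 cm/s, the only actual number available so far. Among the compounds with values here, no measured pair differs in a single place, so the data offer no direct guide to the next change. Compound 3 `O=C(O)CNC(=O)c1c(O)c2c(n(Cc3ccc(Cl)cc3)c1=O)COC2` carries chloro in place of trifluoromethyl on an aromatic carbon, para to a large group (chloro in place of trifluoromethyl on an aromatic carbon). In this assay, the change is expected to produce no step beyond the usual scatter, and no direction is favoured. The estimated step is a 1.1-fold lower number from compound 2 to compound 3 (0.02 log units; within the scatter), which is anchored on compound 2 at 4.2 10^-6 cm/s. For compound 3, the expected value is 4 10^-6 cm/s, within an estimated range of 2 10^-6 cm/s to 8 10^-6 cm/s.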

Compound 3, apparent permeability: 2.5 10^-6 cm/s
Estimate against measurement, compound 3: 1.6-fold (0.20 log units) above; low and high end bracket the measured number.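

Chloro in place of trifluoromethyl on an aromatic carbon, para to a large group, gives the first step that can be read in this assay: a 1.7-fold lower number from compound 2 to compound 3 (0.23 log units; within the scatter). At this place, then, the exchange of these two groups leaves the read-out inside the usual scatter, and compound 2 and compound 3 cannot be put in order. Compound 1 offers a limit of the assay and not a number: the limit of < 1.7 10^-6 cm/s in this assay, at which 1 of the 3 values shown sits.

Compound 1 differs from compound 2 in more than one place, and what each of those differences does on its own cannot be read. From the compounds shown here alone, how a methoxy group or an amine would read at the place now held by chloro also remains open, as only trifluoromethyl and chloro are compared there.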